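The compounds below may be only part of what the source reports. "The series", "measured", "known", "first", "only" and "open" are said of these compounds alone.

Compounds measured in an assay on membranes from brain for displacement of a labelled ligand from Sigma non-opioid intracellular receptor 1 (Cavia porcellus), read by scintillation counting, with a stated time of 120 min; a lower number here means a stronger inhibitor, a higher number a weaker inhibitor:
- compound 1 `CCN1CCN(CCC(=O)Nc2nc3c(C)cccc3s2)CC1` — 543 nM
- compound 2 `Cc1cccc2sc(NC(=O)CCN3CCN(C(C)(C)C)CC3)nc12` — 147 nM
- compound 3 `Cc1cccc2sc(NC(=O)CCN3CCN(CCN(C)C)CC3)nc12` — 1000 nM

Compound 3 has the highest inhibition constant of the three; its nearest neighbour is compound 1, with a 1.8-fold higher number from compound 1 to compound 3 (0.27 log units; within the scatter) (within the scatter), and its furthest is compound 2, with a 6.8-fold higher number from compound 2 to compound 3 (0.83 log units; beyond the scatter).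

Compound 4 `Cc1cccc2sc(NC(=O)CCN3CCN(C4CCCCC4)CC3)nc12` is not yet measured. The change from compound 3 is cyclohexyl in place of 2-(dimethylamino)ethyl on an amine nitrogen in a ring.

Among the compounds with values here, two steps bear on this. The replacement of a smaller hydrocarbon group by a bulkier one on the same ring nitrogen gave a 3.7-fold lower number from compound 1 to compound 2 (0.57 log units; beyond the scatter). The step that put the 2-(dimethylamino)ethyl group in place of tert-butyl gave a 6.8-fold higher number from compound 2 to compound 3 (0.83 log units; beyond the scatter). Reversing that sense and entering a hydrocarbon ring, a step downward beyond the scatter is expected, with a 5.0-fold lower number from compound 3 to compound 4 (0.70 log units; beyond the scatter). For compound 4 the expected inhibition constant is 200 nM, in the range 70 nM to 600 nM.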

Compound 4, inhibition constant: 24 nM
Estimate against measurement, compound 4: 8.3-fold (0.92 log units) above, outside the stated range (below it).
By their numbers in this assay, from the lowest: compound 4; then compound 2; then compounds 1 and 3 (each within the scatter of the next).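

In this assay, cyclohexyl on the amine nitrogen in a ring gives the lowest number of the groups shown at this position, with a 42-fold lower number from compound 3 to compound 4 (1.62 log units; beyond the scatter), a 6.1-fold lower number from compound 2 to compound 4 (0.79 log units; beyond the scatter) and a 23-fold lower number from compound 1 to compound 4 (1.35 log units; beyond the scatter). Among the all-carbon groups, the number falls from ethyl through tert-butyl to cyclohexyl, so the fall seen with tert-butyl does not end there; compound 3, with its 2-(dimethylamino)ethyl group, stands outside this all-carbon sequence. Nothing available gives a reason for these steps.

Still open, from the compounds shown here alone, is whether the ring itself or the number of carbons carries the change, which cyclopentyl, phenyl or a straight hexyl chain on the same nitrogen would help separate. Also open, going by these compounds, is whether a six-membered ring containing oxygen, such as tetrahydropyranyl, would keep the number seen with cyclohexyl.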